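From Butoxycarbonyl to Ethylsulfonyl on the Ring Amine

The compounds below may be only part of what the source reports. "The series", "measured", "known", "first", "only" and "open" are said of these compounds alone.

compound 1 `CC(C)OC(=O)N1CCC(Oc2cccc3c2CCN3c2ccc(S(C)(=O)=O)cc2)CC1`: 70%
compound 2 `CC(C)OC(=O)N1CCC(Oc2ncnc3c2CCN3c2ccc(S(C)(=O)=O)cc2)CC1`: 154%
compound 3 `CCCCOC(=O)N1CCC(Oc2ncnc3c2CCN3c2ccc(S(C)(=O)=O)cc2F)CC1`: 131%

Of the compounds shown here, three have been measured in a functional assay on CHO-K1 cells with Glucose-dependent insulinotropic receptor (Homo sapiens) as the target, read by a luciferase reporter, with a stated time of 5 h; on this read-out lower numbers stand for smaller maximal responses and higher numbers for larger maximal responses. Compound 3 stands second highest of the three. Its nearest neighbour is compound 2, whose number lies higher by more than the usual scatter; its furthest is compound 1, whose number lies far lower, again beyond the scatter. Among the measured compounds shown here, compound 2 and compound 3 differ in more than one place, so no single step between them is defined, and the same holds for every other pair here.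

The next compound, compound 4 `CCS(=O)(=O)N1CCC(Oc2ncnc3c2CCN3c2ccc(S(C)(=O)=O)cc2F)CC1`, differs from compound 3 in one place: ethylsulfonyl in place of butoxycarbonyl on an amine nitrogen in a ring. For the measured compounds named here, no measured pair in this set isolates such a change, so nothing in these data tells how this assay responds to it. Compound 3 already gives a large maximal response, with a value of 131%, and in this assay compound 4 is expected to stay in the same high region. The expected step of a number 11 percentage points lower from compound 3 to compound 4 (beyond the scatter) is a small downward move, within the scatter, an estimate rather than a measured result. Compound 4 is thus expected to give 120%, with a range from 85% to 150%.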

Compound 4, largest response reached (reported as percent of maximum), in percent of the reference or control that the assay uses: 51%
Compound 4: the middle estimate sits 69 percentage points above what was measured; measured number outside the range, below it.
By their numbers in this assay, from the lowest: compound 4; then compound 1; then compound 3; then compound 2.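

This single change shows that the amine nitrogen in the ring is a sensitive place: in this assay, ethylsulfonyl in place of butoxycarbonyl brings a number 80 percentage points lower from compound 3 to compound 4 (beyond the scatter), and the step is large. Among the compounds shown here, until now, no pair had isolated any change at this nitrogen, so the earlier compounds could not show that the maximal response depends so strongly on the group held there. The two groups have the same counts of hydrogen-bond donors and acceptors, neither contains a ring and neither carries a net charge, so those counts do not separate them, and no measured information explains the drop. 

The compounds shown leave open whether the loss follows the sulfonyl link or the shorter chain, and ethoxycarbonyl and butylsulfonyl on this nitrogen would be the groups that pull those two apart. From the compounds shown here alone, it also remains open how a simple amide such as propanoyl would read at this nitrogen, and whether the same swap would cost as much on the core of compound 1.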